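A few compounds are considered here, and "the series" means these few. Any claim that something is new, unique, unknown or untested is made for them only; others in the source may bear on it.

For the measured compounds named here, compound 2 `C=CCc1cc(OC)c(OC(C)C(OCCCCCCCCCC)c2ccc(O)c(OC)c2)c(OC)c1` is the one compound here with an actual number in an assay on HEK293 cells for agonist activity at transient receptor potential cation channel subfamily M member 8 (Homo sapiens), read by fluorescence and calcium flux, with a stated time of 5 min (a higher number here means that more compound is needed for the effect, a lower number that less compound is needed), where compound 2 gives 66 nM. Compound 1 `C=CCc1cc(OC)c(O[C@H](C)[C@@H](O)c2ccc(OC)c(OC)c2)c(OC)c1` reaches only a limit in this assay, reported as > 10000 nM. Compound 3 `C=CCc1cc(OC)c(OC(C)C(O[C@H]2C[C@@H](C)CC[C@@H]2C(C)C)c2ccc(O)c(OC)c2)c(OC)c1` has not yet been measured; it differs from compound 2 by a group of 10 heavy atoms (10 carbon; one six-membered non-aromatic ring of carbon only) in place of a group of 10 heavy atoms (10 carbon; no ring), on an oxygen on a saturated carbon. No measured step of this kind exists among these compounds, so the change is expected to stay within the scatter or bring at most a modest gain, giving an expected step of a 1.7-fold lower number from compound 2 to compound 3 (0.22 log units; within the scatter). Compound 3 is therefore estimated at 40 nM in this assay, with a range from 10 nM to 200 nM.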

Compound 3, half-maximal effective concentration: 11 nM
The estimate for compound 3 lay 3.6-fold (0.56 log units) above the measured number, within the range that was stated.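

On an oxygen on a saturated carbon, replacing the open decyl chain with a six-membered carbon ring of equal heavy-atom count gives a 6.0-fold lower number from compound 2 to compound 3 (0.78 log units; beyond the scatter) in this assay. At this position, then, how the carbons are arranged changes the result, and not only how many there are. Nothing measured here gives a reason for this gain.

Going by these compounds, compound 2 and compound 3 differ in the ring and the stereocentres together, so what each contributes stays open. Also open, on these data alone, is how a shorter hexyl chain, an amine or a phenyl ring would behave on this oxygen.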